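The source may hold more compounds than are shown below. What is called first, only, known or untested is meant among the compounds shown, and "the series" means these compounds.

In an ADME assay on microsomes from liver (Mus musculus) for metabolic stability, read by LC-MS, with a stated time of 10 min, tested at 0.5 uM (a lower number here means that less of the compound is left, a higher number that more of the compound is left), compound 1 (`c1ccc2c(c1)CN[C@H](CN(CCCN1CCNCC1)[C@H]1CCCc3cccnc31)C2`) gives 88% and compound 2 (`c1cnc2c(c1)CN[C@H](CN(CCCN1CCNCC1)[C@H]1CCCc3cccnc31)C2`) gives 63%. Among the measured compounds shown here, compound 2 therefore holds the lower of the two numbers so far, and the single measured step between them is a number 25 percentage points lower from compound 1 to compound 2 (beyond the scatter). Compound 3 (`c1cnc2c(c1)CN[C@@H](CN(CCCN1CCNCC1)[C@H]1CCCc3cccnc31)C2`) has not yet been measured in this assay. Its relation to compound 2 is simple: the two compounds have the same atoms and bonds and differ only in configuration as drawn: 1 of 2 stereo elements differ; a stereocentre at a saturated ring carbon is drawn S in compound 2 and R in compound 3. Nothing leaves and nothing enters, so only the drawn configuration at that saturated ring carbon separates them.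

The measured step bears on this change only indirectly. For the measured compounds named here, it replaces one ring group with another, and no measured pair differs in configuration alone. The data therefore give no size or direction for such a change, and the expectation stays with compound 2. The step expected is no change at the digits printed from compound 2 to compound 3 (within the scatter), an estimate that implies no change beyond the scatter. The range is kept wide, since the step of a number 25 percentage points lower from compound 1 to compound 2 (beyond the scatter) shows that this read-out can move appreciably within the series. Compound 3 is estimated at 63%, with an expected range from 45% to 81%.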

Compound 3, percent of the compound remaining: 78%
Compound 3: middle estimate off by 15 percentage points, on the low side; the range from low to high includes it.
By their numbers in this assay, from the lowest: compound 2; then compounds 3 and 1 (each within the scatter of the next).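

In this assay, the drawn configuration at this saturated ring carbon proves to count on its own, as a number 15 percentage points higher from compound 2 to compound 3 (beyond the scatter) shows, something the earlier pair, which replaced one ring group with another, could not show. This step can be assigned to that configuration alone, because the two structures leave no other difference: the fact that compounds 2 and 3 differ only in the configuration as drawn. The ring group replacement also no longer reads as one fixed step, for ending on the S drawing it is a number 25 percentage points lower from compound 1 to compound 2 (beyond the scatter), whereas ending on the R drawing it is a number 10 percentage points lower from compound 1 to compound 3 (within the scatter).

The compounds shown leave open how the ring group with the carbon-only aromatic ring behaves with the R drawing at this carbon, so the effect of the configuration is known only with the aromatic ring that holds a hetero atom. They also leave open whether the second stereocentre, which is drawn alike in all three compounds, matters in the same way, and whether a fluoro or methoxy group on the aromatic ring would shift the percent remaining in this assay.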